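The compounds below may be only part of what the source reports. "The series", "measured", "known", "first", "only" and "open" are said of these compounds alone.

Within the data shown here, in a functional assay on NCI-H460 cells (Homo sapiens) for antiproliferative activity (on this read-out lower numbers stand for stronger inhibition of growth and higher numbers for weaker inhibition of growth), compound 1 (`Cc1cc(C)c2c(O)cc(-c3cccc(F)c3)nc2n1`) gives 53.7 nM and holds the lower of the two numbers measured so far. Compound 2 (`Cc1cc(C)c2c(O)cc(-c3cccc4ccccc34)nc2n1`) gives 631 nM on the same read-out, a higher number by a margin beyond the scatter. Compound 3 (`Cc1cccc(-c2cc(O)c3c(C)cc(C)nc3n2)c1`) has not yet been measured. It departs from compound 1 at one place, with methyl in place of fluoro on an aromatic carbon, meta to a large group (methyl in place of fluoro on an aromatic carbon). Among the measured compounds shown here, no measured pair shows this exchange, so the data offer no direct guide to its size. The only measured contrast is that between compound 1 and compound 2, and it concerns a different structural change. A modest step toward a higher number is expected in this assay, close to the edge of the scatter and smaller than the gap between those two compounds. The estimated move is a 2.0-fold higher number from compound 1 to compound 3 (0.31 log units; beyond the scatter) on this read-out. Compound 3 is expected at 110 nM with an estimated range of 35 nM to 350 nM in this assay.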

Compound 3, concentration for 50% growth inhibition: 44700 nM
Compound 3: the middle estimate sits 410-fold (2.61 log units) below what was measured, and the stated range ends below it.
By their numbers in this assay, from the lowest: compound 1; then compound 2; then compound 3.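

Putting methyl in place of fluoro on this aromatic carbon, meta to a large group, brings an 830-fold higher number from compound 1 to compound 3 (2.92 log units; beyond the scatter) in this assay, the first direct measure of this exchange and a large one. Fluoro and methyl each count as 1 heavy atom, and neither brings a ring, a hydrogen-bond donor or acceptor, or a net charge, so these counts do not separate the two groups, yet this one exchange leaves compound 3 with far weaker inhibition of growth than compound 1. Nothing measured here explains why this exchange carries so much weight.

The compounds shown leave open whether the large step reflects something gained with methyl or something lost with fluoro, and a plain hydrogen, chloro, methoxy or an amine at this carbon would be needed to tell where the steep change sets in. They also leave open whether the same exchange would have a step of similar size on another carbon of this ring, or on a core carrying other groups.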